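Shifting the chlorine on the chlorophenyl arm

The compounds below may be only part of what the source reports. "The series", "measured", "known", "first", "only" and "open" are said of these compounds alone.

Compound 3 `Oc1ccc(-c2cc(-c3ccc(Cl)cc3)nc(-c3ccco3)c2)cc1` is the most active of the two compounds with a number: in a functional assay on T47D cells (Homo sapiens) for cytotoxicity, read by CCK-8 assay and cell counting, with a stated time of 2 days (a lower number here means a stronger inhibitor, a higher number a weaker inhibitor), compound 3 gives 6260 nM, while compound 1 `Oc1ccc(-c2cc(-c3cccc(Cl)c3)nc(-c3ccccn3)c2)cc1` gives 27900 nM, a gap that lies beyond the scatter. Compound 2 `Oc1ccc(-c2cc(-c3ccncc3)nc(-c3cccc(Cl)c3)c2)cc1` has no result in this assay, as compound 2 is recorded as "not determined" (no result reported). Among the compounds with values here, compound 1 and compound 3 differ in more than one place, so no single step between them can be read.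

Compound 4 `Oc1ccc(-c2cc(-c3cccc(Cl)c3)nc(-c3ccco3)c2)cc1` has not been measured in this assay. Its difference from compound 3: 3-chlorophenyl in place of 4-chlorophenyl on an aromatic carbon. The two have the same atoms, joined differently. Within the data shown here, no step between measured compounds covers this change, so the expectation rests on compound 3 alone. Such a change is expected to give a step of modest size, within or just beyond the scatter, and if anything toward a weaker inhibitor. Compound 4 is estimated at 8000 nM, with a range from 3000 nM to 25000 nM, which corresponds to an expected step of a 1.3-fold higher number from compound 3 to compound 4 (0.11 log units; within the scatter).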

Compound 4, half-maximal inhibitory concentration: 5220 nM
The estimate for compound 4 lay 1.5-fold (0.19 log units) above the measured number, within the range that was stated.
By their numbers in this assay, from the lowest: compounds 4 and 3 (each within the scatter of the next); then compound 1.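

With 3-chlorophenyl in place of 4-chlorophenyl, this assay shows a 1.2-fold lower number from compound 3 to compound 4 (0.08 log units; within the scatter), so the chlorine placement on this arm, at this position on the core, is not resolved by the assay. Compound 4 also gives the series its first link to compound 1 that differs in one place: furan-2-yl in place of pyridin-2-yl gives a 5.3-fold lower number from compound 1 to compound 4 (0.73 log units; beyond the scatter), so among the compounds shown, only this change gives a step beyond the scatter. No measurement at hand accounts for either step.

From the compounds shown here alone, it remains open whether the furan-2-yl step carries over to a compound with a 4-chlorophenyl arm. Also open, going by these compounds, is how an amine or a carboxylic acid in place of the chlorine on that arm would read in this assay.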